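Three Amides on a Shared Core, Two Already at the Limit

The source may hold more compounds than are shown below. What is called first, only, known or untested is meant among the compounds shown, and "the series" means these compounds.

Compound 1 `COc1ccc(-c2cnc(NC(=O)c3ccccn3)n2C)cc1` was tested in a toxicity assay on THP-1 cells (Homo sapiens) for inhibition; a lower number here means that less compound is tolerated, a higher number that more compound is tolerated. In this assay compound 1 gives > 100000 nM, which is a limit of the assay rather than a measured number. Compound 2 `COc1ccc(-c2cnc(NC(=O)C3CCNCC3)n2C)cc1` differs from it only at the amide. In this assay compound 2 gives > 100000 nM, again a limit and not a number. The step that the two limits leave unreadable from compound 1 to compound 2 therefore cannot be read, as the limit of > 100000 nM in this assay, at which 2 of the 2 values shown sit, shows. Within the data shown here, compound 2 thus stands only at a limit, and the one other value shown beside it is a limit as well.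

Compound 3 `COc1ccc(-c2cnc(NC(=O)c3cccc(C)c3)n2C)cc1` is not yet measured. Its change from compound 2 is 3-methylphenyl in place of piperidin-4-yl on a carbonyl carbon. Among the measured compounds shown here, no measured step bears on this change in a readable way, so no size or direction can be taken from the data, only that both measured compounds were tolerated up to the limit. Compound 3 is therefore expected to sit near the same limit, with an estimated step of a number no higher from compound 2 to compound 3 (the limit leaves the size open). The estimate for compound 3 is 100000 nM, within a range from 30000 nM to 300000 nM.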

Compound 3, half-maximal cytotoxic concentration: > 100000 nM
Compound 3: no number, only a limit; the forecaster's own chance of this, stated with the estimate: 70%; the middle value sits exactly at the limit.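

In this assay compound 3 gives > 100000 nM, which is a limit of the assay and not a number. The steps to compound 3 from compound 1 and compound 2 therefore cannot be read: the limit of > 100000 nM in this assay, at which 3 of the 3 values shown sit. The compounds shown leave open at what concentration each becomes toxic to these cells, and whether swapping pyridin-2-yl, piperidin-4-yl and 3-methylphenyl on the amide changes that concentration at all.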